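Furan replacement on a pair held at the assay limit

The source may report more compounds than this note shows. Statements on the series, on what has been measured and on what is new or still open speak of the compounds shown alone.

Compound 1 `O=c1[nH]cnc2c1c(-c1cc3ccccc3o1)cn2[C@@H]1O[C@H](CO)[C@@H](O)[C@H]1O` carries a 1-benzofuran-2-yl group on the five-membered ring of the shared core. In a functional assay on A549 cells (Homo sapiens), read by MTT assay, with a stated time of 72 h (a higher number here means a weaker inhibitor, a lower number a stronger inhibitor), compound 1 gives > 20000 nM, which is a limit of the assay rather than a number. Compound 2 `CNc1ncnc2c1c(-c1ccoc1)cn2[C@@H]1O[C@H](CO)[C@@H](O)[C@H]1O` differs from compound 1 in two places, with a methylamino group on the core and a furan-3-yl group on the five-membered ring. In this assay compound 2 gives > 20000 nM, again a limit rather than a number. Within the data shown here, no step between two measured compounds can be taken here, and the limit of > 20000 nM in this assay, at which 2 of the 2 values shown sit, is the whole of the evidence: compound 1 is not ranked by any number, only held under a limit. Compound 3 `O=c1[nH]cnc2c1c(-c1ccoc1)cn2[C@@H]1O[C@H](CO)[C@@H](O)[C@H]1O` is compound 1 with furan-3-yl in place of 1-benzofuran-2-yl on an aromatic carbon. Compound 2 carries the same furan-3-yl group and reaches only a limit, so nothing seen here points to the smaller group bringing compound 3 into the measurable range. The step from compound 1 to compound 3 is expected to be a step that the limit leaves unreadable from compound 1 to compound 3, that is, no change the numbers can resolve. For compound 3 the estimate in this assay is 30000 nM, with a range from 10000 nM to 100000 nM, and most likely only a limit will again be reported.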

Compound 3, half-maximal inhibitory concentration: > 20000 nM
Compound 3: no number, only a limit (the forecaster's own chance of this, stated with the estimate: 85%); the middle value lies beyond the limit too.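

In this assay compound 3 gives > 20000 nM, a limit rather than a number. No step can be read between compound 1 and compound 3, so the change from 1-benzofuran-2-yl to furan-3-yl has no measurable size: the limit of > 20000 nM in this assay, at which 3 of the 3 values shown sit. The compounds shown leave open whether any group on this aromatic carbon brings the shared core into the measurable range.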